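Removing a chloro from a dichloropurine core

The source may hold more compounds than are shown below. What is called first, only, known or untested is meant among the compounds shown, and "the series" means these compounds.

Measured compounds:
compound 1 `ClCc1ccc(Cn2cnc3c(Cl)ncnc32)cc1` 3460 nM
compound 2 `ClCc1ccccc1Cn1cnc2c(Cl)nc(Cl)nc21` 3380 nM

In a functional assay on SF-295 cells (Homo sapiens) for cytotoxicity, read by sulforhodamine B assay, with a stated time of 48 h (on this read-out lower numbers stand for stronger inhibition of growth and higher numbers for weaker inhibition of growth), compound 2 gives 3380 nM. That is the lowest of the two numbers, but the nearest neighbour, compound 1, gives 3460 nM, a gap within the scatter, so the two cannot be ordered. The step to compound 3 `ClCc1ccccc1Cn1cnc2c(Cl)ncnc21` changes only the core: hydrogen in place of chloro on an aromatic carbon. Among the compounds with values here, no step between measured compounds mirrors this change, so the size of the step can only be estimated. Compound 3 shares its core with compound 1. Compound 1, at 3460 nM, serves as the reference. Compound 3 is expected to sit close to both measured compounds, with a step from compound 2 of a 1.0-fold higher number from compound 2 to compound 3 (0.02 log units; within the scatter) that should stay within the scatter. Compound 3 is estimated at 3500 nM, in a range from 1500 nM to 8000 nM.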

Compound 3, concentration for total growth inhibition: 23400 nM
Estimate against measurement, compound 3: 6.7-fold (0.83 log units) below; the measured number lies above the stated range.
By their numbers in this assay, from the lowest: compounds 2 and 1 (each within the scatter of the next); then compound 3.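

In this assay, within the data shown here, the chloro on the aromatic carbon between two ring nitrogen atoms turns out to matter: hydrogen in its place gives a 6.9-fold higher number from compound 2 to compound 3 (0.84 log units; beyond the scatter), the only step in this set that can be read. Compound 3 shares its core with compound 1, which gives 3460 nM, so the core without this chloro does not by itself bring the higher number seen for compound 3. The step therefore rests on one pair and holds only for the chloromethyl placement shared by compound 2 and compound 3.

As far as these compounds go, whether an amine or a methoxy group on this carbon would stay with compound 2 or fall in with compound 3 remains open. Nothing measured here gives a reason for the step.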